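The compounds below may be only part of what the source reports. "The series", "measured", "known", "first", "only" and "open" are said of these compounds alone.

Compound 1, with the structure `O=C(COc1ccc2c(=O)c(-c3ccccc3)coc2c1)Nc1ccc2ccccc2c1`, is the starting point of this comparison. Going by the values given here, in a functional assay on NPC-TW01 cells (Homo sapiens) for antiproliferative activity, read by MTT assay, with a stated time of 72 h (a higher number here means a weaker inhibitor of growth, a lower number a stronger inhibitor of growth), compound 1 gives 1370 nM, and this is the only outright number among the two values shown. Compound 2, with the structure `O=C(COc1c(-c2ccccc2)oc2ccccc2c1=O)Nc1ccc(-c2ccccc2)cc1`, is reported in this assay as > 10000 nM, which is a limit of the assay rather than a measured number. The evidence on the measured values therefore amounts to one point: the limit of > 10000 nM in this assay, at which 1 of the 2 values shown sits.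

Compound 3, with the structure `O=C(COc1ccc2c(=O)c(-c3ccccc3)coc2c1)Nc1ccccc1`, has not yet been tested. It differs from compound 1 in a single place: phenyl in place of naphthalen-2-yl on an amide-type nitrogen. Among the compounds with values here, no pair of measured compounds differs by exactly this change, so the size of the step is not known from the data. The expectation is that the smaller aromatic group gives a weaker inhibitor of growth, by a step of a 2.6-fold higher number from compound 1 to compound 3 (0.41 log units; beyond the scatter), which is modestly beyond the usual scatter. Compound 3 is thus expected to give about 3500 nM in this assay, with a likely range from 1200 nM to 10000 nM.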

Compound 3, concentration for 50% growth inhibition: > 10000 nM
Compound 3 was reported as a limit; the forecaster's own chance of this, stated with the estimate: 25%; middle value at least 2.8-fold (0.45 log units) away from the limit.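

The step of phenyl in place of naphthalen-2-yl on an amide-type nitrogen can now be read in this assay: it is an at least 7.2-fold higher number from compound 1 to compound 3 (0.86 log units; beyond the scatter), which lies beyond the usual scatter. With the core of compound 1 unchanged, the group on this nitrogen therefore matters greatly, and removing one of the two aromatic rings of naphthalen-2-yl is enough to lose a measurable value in this assay. The result for compound 3 is a limit and not a number, so the step shows only a minimum size, and the data are increasingly bounded in the same way: the limit of > 10000 nM in this assay, at which 2 of the 3 values shown sit.

Going by these compounds, it remains open whether growth inhibition could be recovered on this nitrogen by a phenyl carrying a chlorine atom or a methoxy group, or by another two-ring group such as quinolin-2-yl or naphthalen-1-yl. The compounds shown also do not reveal why the second aromatic ring counts for so much, as no property that could explain the difference is given for either compound.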